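The source may report more compounds than this note shows. Statements on the series, on what has been measured and on what is new or still open speak of the compounds shown alone.

Measured compounds:
Compound 1 `C=C1CC[C@@H]2[C@](C)(CO)[C@H](O)CC[C@@]2(C)[C@@H]1CCC1=CCOC1=O` — in a functional assay on RAW264.7 cells (Mus musculus) for inhibition, read by Griess assay, with a stated time of 24 h (on this read-out higher numbers stand for weaker inhibition and lower numbers for stronger inhibition), compound 1 gives 21000 nM.
Compound 2 `C[C@@]1(CO)[C@H](O)CC[C@@]2(C)C(CCC3=CCOC3=O)=C(CO)CC[C@H]12` — compound 2 reaches only the assay limit > 100000 nM.
Compound 3 `C[C@@]1(CO)[C@H](O)CC[C@@]2(C)C(CCC3=CCOC3=O)=C(C=O)CC[C@H]12` — compound 3 likewise reaches only the assay limit > 100000 nM.

Compound 1 is the only one of the three that yields a number in this assay; the other two stop at a limit, which is the limit of > 100000 nM in this assay, at which 2 of the 3 values shown sit. Within the data shown here, the one step that can be read between measured compounds, a step that the two limits leave unreadable from compound 2 to compound 3, runs between two limits and so gives no size at all.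

Compound 4 `C=C1[C@@H](CCC2=CCOC2=O)[C@]2(C)CC[C@@H](O)[C@@](C)(CO)[C@H]2C[C@@H]1O` differs from compound 1 in one place: hydroxy in place of hydrogen on a saturated ring carbon. Among the measured compounds shown here, no measured step involves a hydroxy entering on a saturated ring carbon, so nothing here tells the direction or size of this change. With compound 1 at 21000 nM as the only anchor, the step to compound 4 is expected to stay within the scatter, and the estimated step is a 1.4-fold higher number from compound 1 to compound 4 (0.15 log units; within the scatter). Compound 4 is therefore expected to give about 30000 nM, with a range from 8000 nM to 100000 nM.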

Compound 4, half-maximal inhibitory concentration: > 100000 nM
Compound 4 ended at the assay's limit (the forecaster's own chance of this, stated with the estimate: 25%); at least 3.3-fold (0.52 log units) between middle value and limit.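

Among these compounds, this is the first step in this assay that can be read, and it concerns a change on this saturated ring carbon: hydroxy in place of hydrogen gives an at least 4.7-fold higher number from compound 1 to compound 4 (0.67 log units; beyond the scatter). As far as these compounds go, on this read-out, a higher number means weaker inhibition, so adding a hydroxy here on the core of compound 1 clearly costs activity, and the true size of the loss remains unknown. The value of compound 4 is only a limit, and compound 4 now sits with most of the compounds shown: the limit of > 100000 nM in this assay, at which 3 of the 4 values shown sit.

The compounds shown leave open whether this loss is specific to the hydroxy or would also appear with another group on the same carbon, such as a methoxy or an amine. They also leave open whether a hydroxy pointing the opposite way on this carbon would give the same result.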